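The source may hold more compounds than are shown below. What is called first, only, known or untested is meant among the compounds shown, and "the series" means these compounds.

Compound 2, whose structure is `COC(=O)C(CCCN(C)CCCc1nc2ccccc2[nH]1)(c1ccc(Br)cc1)C(C)C`, gives 8.17 nM in a functional assay on HEK293 cells for antagonist activity at Voltage-dependent T-type calcium channel subunit alpha-1G (Homo sapiens), read by patch clamp; a lower number here means a stronger inhibitor, a higher number a weaker inhibitor. For the measured compounds named here, this is the lower of the two numbers measured so far; compound 1, with the structure `COC(=O)C(CCCN(C)CCCc1nc2cc(OC)ccc2[nH]1)(c1ccc(OC)cc1)C(C)C`, gives 880 nM in this assay, and the two compounds differ from each other in two places, so no single step links them. Compound 3, with the structure `COC(=O)C(CCCN(C)CCCc1nc2cc(C)c(C)cc2[nH]1)(c1ccc(Br)cc1)C(C)C`, has not yet been measured; it differs from compound 2 by 5,6-dimethyl-1H-benzimidazol-2-yl in place of 1H-benzimidazol-2-yl on a saturated chain carbon, three bonds along the chain from an amine nitrogen. Going by the values given here, there is no measured step of this kind to lean on, and the only other compound with a substituted benzimidazole, compound 1, also carries a different group on the aryl ring. The step is therefore expected to be modest, within or just beyond the scatter, with a slight drift toward a weaker inhibitor held as the more likely direction. The expected step from compound 2 to compound 3 is a 1.7-fold higher number from compound 2 to compound 3 (0.23 log units; within the scatter). For compound 3 the estimate in this assay is 14 nM, with a range from 3.5 nM to 55 nM.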

Compound 3, half-maximal inhibitory concentration: 53 nM
Estimate against measurement, compound 3: 3.8-fold (0.58 log units) below; the range from low to high includes it.
By their numbers in this assay, from the lowest: compound 2; then compound 3; then compound 1.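

For the compounds shown here, the replacement of 1H-benzimidazol-2-yl by 5,6-dimethyl-1H-benzimidazol-2-yl gives, in this assay, a 6.5-fold higher number from compound 2 to compound 3 (0.81 log units; beyond the scatter), the first single change that can be read at this place, on a saturated chain carbon, three bonds along the chain from an amine nitrogen. Adding the two methyl groups to this group therefore weakens inhibition measurably, which compound 1 could not show, as it differs from compound 2 in a second place as well. Nothing at hand gives a reason for this step.

The compounds shown leave open whether a single methyl group would give a step of similar size, and whether fluorine or chlorine in place of the methyl groups would do the same. They also leave open whether the step would hold with a methoxy group in place of the bromine on the aryl ring.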